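The source may report more compounds than this note shows. Statements on the series, on what has been measured and on what is new or still open speak of the compounds shown alone.

Measured compounds in a functional assay on the whole organism with Rattus norvegicus as the target, at a dose of 100 mg/kg; on this read-out lower numbers stand for less inhibition and higher numbers for more inhibition at the one dose given (going by the name of the read-out):
- compound 1 `CN(C)/C(=N/CCCCn1nc(-c2ccccc2)ccc1=O)NC#N`: 80.7%
- compound 2 `O=c1ccc(-c2ccccc2)nn1CCCC/N=C(\S)Nc1ccc(F)cc1`: 45.6%
- compound 3 `C#CCN/C(=N/CCCCn1nc(-c2ccccc2)ccc1=O)NC#N`: -12.9%

Compound 1 stands highest of the three; compound 2 is nearest and lies lower beyond the scatter, compound 3 lies far lower still. Within the data shown here, the only single-point step recorded runs a number 93.6 percentage points lower from compound 1 to compound 3 (beyond the scatter): a change at the same carbon with a double bond to nitrogen, and the inhibition collapses to nothing.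

Compound 4 `N#CNC(=N)NCCCCCCn1nc(-c2ccccc2)ccc1=O` has the same atoms as compound 1 but joined differently: a group of 8 heavy atoms (4 carbon, 4 nitrogen; no ring) in place of a group of 8 heavy atoms (4 carbon, 4 nitrogen; no ring), on a saturated chain carbon, four bonds along the chain from an aromatic nitrogen. The cyanoguanidine end is thus kept, but what sits on it and how far it lies from the core both change at once. The step from compound 1 to compound 3 bears on this: it shows that altering the amine end of the cyanoguanidine costs a large amount. Among the measured compounds shown here, no measured step shows a chain lengthened by this count. The expectation is a drop in this assay for compound 4, smaller than the collapse seen for compound 3 since the donor-rich unsubstituted end is not the propargyl case, yet clearly beyond the scatter. Compound 4 is estimated at 35% (range -10% to 75%), a step of a number 45.7 percentage points lower from compound 1 to compound 4 (beyond the scatter) expected.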

Compound 4, a percentage reported as inhibition, in the whole organism at one dose (the size of the read-out at that dose, not a potency): 20.5%
Compound 4: middle estimate off by 14.5 percentage points, on the high side; measured number inside the range.
By their numbers in this assay, from the lowest: compound 3; then compound 4; then compound 2; then compound 1.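

In this assay, the step of a number 60.2 percentage points lower from compound 1 to compound 4 (beyond the scatter) shows that keeping the same atoms in the group on a saturated chain carbon, four bonds along the chain from an aromatic nitrogen, does not keep the inhibition, so the atom count of that group alone does not account for the number at this dose. The earlier step at this end, with propargylamino in place of dimethylamino, changed only the amine end; here the entering group has 3 hydrogen-bond donors where the leaving group has 1 hydrogen-bond donor, and the distance from the core changes as well, yet compound 4 still gives 20.5%. No measurement shown gives a reason for the loss.

The compounds shown leave open how much of the step belongs to the chain and how much to the unsubstituted cyanoguanidine end, since the two changes arrive together. A dimethylamino end on the longer chain of compound 4 would separate them, and a methylamino or piperidine group on the chain of compound 1 would show how the amine end behaves between the extremes seen so far.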